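This account rests on a few compounds, and the source may have more. Where it says the series, first, only, none or still open, it means among the compounds named here.

Working notes on the cinnamamide series tested in a functional assay on DU-145 cells (Homo sapiens) for cytotoxicity, read by MTT assay, with a stated time of 72 h; a higher number here means a weaker inhibitor, a lower number a stronger inhibitor. Compound 1 `COc1cccc(/C=C/C(=O)Nc2cc(OC)c(OC)c(OC)c2)c1` gives 3200 nM in this assay. Compound 2 `C#CCOc1cccc(/C=C/C(=O)Nc2cc(C(=O)c3cc(OC)c(OC)c(OC)c3)ccc2OC)c1`, which carries a propargyloxy group on the cinnamoyl ring and a benzophenone-type right-hand part, gives 15800 nM. Compound 3 `COc1cc(C(=O)c2cc(OC)c(OC)c(OC)c2)cc(NC(=O)/C=C/c2cc(OC)c(OC)c(OC)c2)c1OC` gives 6600 nM in this assay. On these three numbers compound 3 stands second highest: its nearest neighbour is compound 1, whose number is lower by a step beyond the scatter, and its furthest is compound 2, whose number is higher, again beyond the scatter.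

Compound 4 `COc1cc(C(=O)c2cc(OC)c(OC)c(OC)c2)cc(NC(=O)/C=C/c2cc(F)c(F)c(F)c2)c1OC` is not yet measured. It differs from compound 3 in one place: 3,4,5-trifluorophenyl in place of 3,4,5-trimethoxyphenyl on a double-bonded chain carbon bound to a double-bonded chain carbon. No measured pair in this set isolates such a change, so no direction can be read off from shown steps. Expectation: a step that is small and, if anything, toward a higher number, quite possibly not beyond the scatter, and the estimate is anchored on compound 3 at 6600 nM. For compound 4 in this assay the expected value is 9000 nM, with a range from 3000 nM to 30000 nM. This estimate means an expected step of a 1.4-fold higher number from compound 3 to compound 4 (0.13 log units; within the scatter), the range left wide since no shown step supports the change.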

Compound 4, half-maximal inhibitory concentration: 7900 nM
Estimate against measurement, compound 4: 1.1-fold (0.06 log units) above, within the range that was stated.
By their numbers in this assay, from the lowest: compound 1; then compounds 3, 4 and 2 (each within the scatter of the next, the first and the last beyond it).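

In this assay, going by these compounds alone, the exchange of 3,4,5-trimethoxyphenyl for 3,4,5-trifluorophenyl on a double-bonded chain carbon bound to a double-bonded chain carbon gives a 1.2-fold higher number from compound 3 to compound 4 (0.08 log units; within the scatter) and is the only single-place step so far. On the core of compound 3, this position therefore takes a group with 0 hydrogen-bond acceptors and 9 heavy atoms in place of one with 3 hydrogen-bond acceptors and 12 heavy atoms, with no step beyond the scatter. No measurement at hand offers an explanation for this outcome.

Still open, on these data alone, is whether a group of another kind at this place, such as a phenyl ring carrying an amine or a carboxylic acid, would move the number beyond the scatter from compound 3. One single-place pair also cannot show whether the same exchange would give a similar step on a different core, so the result holds only for the pair of compound 3 and compound 4.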